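Nitro on the benzyl ring of a macrocyclic anilinoquinazoline

The source may report more compounds than this note shows. Statements on the series, on what has been measured and on what is new or still open speak of the compounds shown alone.

Compound 1, `c1ccc(COc2ccccc2Nc2ncnc3cc4c(cc23)OCCOCCOCCO4)cc1`: 37300 nM
Compound 2, `FC(F)(F)c1ccc(COc2ccccc2Nc2ncnc3cc4c(cc23)OCCOCCO4)cc1`: a limit, > 100000 nM
Compound 3, `FC(F)(F)c1ccc(COc2cccc(Nc3ncnc4cc5c(cc34)OCCOCCOCCO5)c2)cc1`: 34000 nM

In a functional assay on HepG2 cells (Homo sapiens) for antiproliferative activity, read by MTT assay, with a stated time of 72 h (on this read-out higher numbers stand for weaker inhibition and lower numbers for stronger inhibition), compound 1 gives 37300 nM, the highest of the two numbers shown. Compound 3 gives 34000 nM, which lies within the scatter of compound 1, so no order between them can be read. For compound 2 this assay reports only a limit, > 100000 nM, at which one of the three values sits (the limit of > 100000 nM in this assay, at which 1 of the 3 values shown sits).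

Compound 4, `O=[N+]([O-])c1ccc(COc2ccccc2Nc2ncnc3cc4c(cc23)OCCOCCOCCO4)cc1`, differs from compound 1 by nitro in place of hydrogen on an aromatic carbon. Within the data shown here, no measured pair shows this exact change, so its size is unknown. A step of modest size toward weaker inhibition is expected, a 1.5-fold higher number from compound 1 to compound 4 (0.17 log units; within the scatter), and compound 4 is estimated at 55000 nM, between 18000 nM and 170000 nM.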

Compound 4, half-maximal inhibitory concentration: 60800 nM
The estimate for compound 4 lay 1.1-fold (0.04 log units) below the measured number, within the range that was stated.
By their numbers in this assay, from the lowest: compounds 3, 1 and 4 (each within the scatter of the next). At a limit, above all of these: compound 2.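

In this assay, the change from benzyl to 4-nitrobenzyl gives a 1.6-fold higher number from compound 1 to compound 4 (0.21 log units; within the scatter). Among these compounds, this is the first direct reading of a change at this place on the benzyl ring, and with nitro there the two numbers cannot be put in order. Nothing shown offers a cause for this step.

From the compounds shown here alone, it remains open whether an amine or a carboxylic acid at the same place would give a step beyond the scatter. Also open, going by these compounds, is whether nitro would read the same with the benzyloxy group placed as in compound 3.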